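Alkenyl branch substituent series: cyclohexyl analogue

The source may hold more compounds than are shown below. What is called first, only, known or untested is meant among the compounds shown, and "the series" means these compounds.

Measured compounds:
compound 1 `CCCCCCCC/C(=C\C=C\C(=O)N[C@H](C)CCCc1cccnc1)c1ccc(OC)cc1` gives 0.1 mg/kg in a functional assay with platelet-activating factor receptor (Cavia porcellus) as the target; a higher number here means that more compound is needed for the effect, a lower number that less compound is needed
compound 2 `CC/C(=C\C=C\C(=O)N[C@H](C)CCCc1cccnc1)c1ccc(OC)cc1` gives 0.68 mg/kg in this assay
compound 3 `COc1ccc(/C(=C/C=C/C(=O)N[C@H](C)CCCc2cccnc2)C(C)C)cc1` gives 0.41 mg/kg in this assay

Compound 3 stands second highest of the three numbers. Its nearest neighbour is compound 2, a gap that lies within the scatter (a 1.7-fold lower number from compound 2 to compound 3 (0.22 log units; within the scatter)); its furthest is compound 1, a gap beyond the scatter (a 4.1-fold higher number from compound 1 to compound 3 (0.61 log units; beyond the scatter)).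

Compound 4 `COc1ccc(/C(=C/C=C/C(=O)N[C@H](C)CCCc2cccnc2)C2CCCCC2)cc1` is not yet measured. It differs from compound 3 by cyclohexyl in place of isopropyl on a double-bonded chain carbon bound to an aromatic carbon and a double-bonded chain carbon.

Among the compounds with values here, two measured steps bear on this change. The step of a 4.1-fold higher number from compound 1 to compound 3 (0.61 log units; beyond the scatter) shows that replacing octyl by isopropyl at this place raises the number by a modest amount. The step of a 6.8-fold higher number from compound 1 to compound 2 (0.83 log units; beyond the scatter) shows a somewhat larger rise when the chain at this place is cut to ethyl. Both point the same way: more carbon at this position goes with a lower number. Cyclohexyl brings the carbon count at this position back toward that of compound 1, so a modest step downward in this assay is expected, of about a 1.9-fold lower number from compound 3 to compound 4 (0.27 log units; within the scatter), though the ring is new to the series and no measured step tests a ring here. Compound 4 is therefore estimated at 0.22 mg/kg, with a range from 0.08 mg/kg to 0.6 mg/kg.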

Compound 4, dose for 50% inhibition: 0.21 mg/kg
Beside the measured number, compound 4's estimate is 1.0-fold (0.02 log units) above it, within the range that was stated.
By their numbers in this assay, from the lowest: compound 1; then compounds 4, 3 and 2 (each within the scatter of the next, the first and the last beyond it).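

In this assay, a ring is tolerated on the double-bonded chain carbon bound to an aromatic carbon and a double-bonded chain carbon: the change to cyclohexyl from isopropyl gives a 2.0-fold lower number from compound 3 to compound 4 (0.29 log units; within the scatter) and so does not separate the two groups, while the change from ethyl gives a 3.2-fold lower number from compound 2 to compound 4 (0.51 log units; beyond the scatter) and does separate them. Octyl keeps the lowest number of the four, and the comparison with cyclohexyl gives a 2.1-fold higher number from compound 1 to compound 4 (0.32 log units; beyond the scatter) as a step beyond the scatter, so at this place the ring does not match the open octyl chain, although the series now shows that a chain is not required for a number well clear of that of compound 2. Nothing on hand gives a reason for these differences.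

Still open, on these data alone, is whether a chain longer than octyl lowers the number further, or whether a point is reached where it rises again. Also open, as far as these compounds go, is how a cyclopentyl ring, a phenyl ring or a chain ending in an amine or a carboxylic acid would behave at this place, since all four compounds carry only carbon groups without a donor or acceptor here.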